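The compounds below may be only part of what the source reports. "The series", "measured", "known", "first", "only" and "open" are said of these compounds alone.

Compound 1, with the structure `CN(C)C(=O)c1cc2cnc(Nc3ccc(NC(=O)C4(C(=O)Nc5ccc(F)cc5)CC4)cc3)nc2n1C1CCCC1`, gives 105% in a functional assay on T47D cells (Homo sapiens) for inhibition, read by CCK-8 assay, with a stated time of 72 h, tested at 10 uM; a higher number here means more inhibition of growth at the concentration tested, a lower number less inhibition of growth. Of the two measured compounds it stands highest: the nearest is compound 2, with the structure `CN(C)C(=O)c1cc2cnc(Nc3ccc(NC(=O)C4(C(=O)Nc5cccc(O)c5)CC4)cc3)nc2n1C1CCCC1`, which in this assay reaches 83.7%. Among the measured compounds shown here, the only measured step, a number 21.3 percentage points lower from compound 1 to compound 2 (beyond the scatter), comes from putting 3-hydroxyphenyl in place of 4-fluorophenyl on an amide-type nitrogen. Compound 3, with the structure `COc1ccc(NC(=O)C2(C(=O)Nc3ccc(Nc4ncc5cc(C(=O)N(C)C)n(C6CCCC6)c5n4)cc3)CC2)cc1`, has not yet been measured. It differs from compound 1 by methoxy in place of fluoro on an aromatic carbon, with methoxy in place of fluoro on an aromatic carbon. For the measured compounds named here, that is a smaller change than the one behind compound 2, since the group stays at the same place on the ring, so only a small drop beyond the scatter, or none, is expected in this assay. The estimate for compound 3 is therefore 95%, within 75% to 108%, an expected step of a number 10 percentage points lower from compound 1 to compound 3 (within the scatter).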

Compound 3, percent growth inhibition at one concentration: 96.1%
Estimate against measurement, compound 3: 1.1 percentage points below; measured number inside the range.
By their numbers in this assay, from the lowest: compound 2; then compounds 3 and 1 (each within the scatter of the next).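

In this assay, methoxy on the aromatic carbon para to a large group, where compound 1 carries fluoro, gives a number 8.9 percentage points lower from compound 1 to compound 3 (within the scatter), so at this position the two groups cannot be told apart, even though methoxy brings one more heavy atom and a hydrogen-bond acceptor. The ring with the methoxy group also gives a number 12.4 percentage points higher from compound 2 to compound 3 (beyond the scatter), but that step changes both the group and its place on the ring, so it cannot show which of the two matters. Nothing measured here explains why these numbers differ or match.

The compounds shown leave open whether 3-methoxyphenyl or 4-hydroxyphenyl would separate the effect of the group from that of its place on the ring. They also leave open whether an amine or a carboxylic acid at this position would keep the growth inhibition seen with fluoro and methoxy.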